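A larger ring group in place of 4-methylpiperazin-1-yl

The compounds below may be only part of what the source reports. "The series", "measured", "known", "first", "only" and "open" are said of these compounds alone.

Compound 1 `Cc1ccc(-c2cc(C(=O)NCCN3CCCCC3)c3cc(Cl)ccc3n2)cc1`: 7000 nM
Compound 2 `Cc1cc(Nc2cc(C(=O)NCCN3CCCC3)c3cc(F)ccc3n2)on1`: > 50000 nM
Compound 3 `CN1CCN(c2cc(C(=O)NCCN3CCCC3)c3cc(F)ccc3n2)CC1`: 20000 nM

All three were tested in an ADME assay on MRC5 cells (Homo sapiens) for antiproliferative activity, read by fluorescence and resazurin assay, with a stated time of 68 h; on this read-out higher numbers stand for an effect only at larger amounts of compound and lower numbers for an effect already at smaller amounts. Compound 2 gives > 50000 nM, which is a limit of the assay and not a number. Of the two true numbers, compound 3 has the higher at 20000 nM, with compound 1 at 7000 nM.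

Compound 4 `O=C(NCCN1CCCC1)c1cc(N2CCn3ccnc3C2)nc2ccc(F)cc12` differs from compound 3 on one aromatic carbon: a group of 9 heavy atoms (6 carbon, 3 nitrogen; one five-membered aromatic ring with 2 hetero atoms, one six-membered non-aromatic ring with 2 hetero atoms) in place of a group of 7 heavy atoms (5 carbon, 2 nitrogen; one six-membered non-aromatic ring with 2 hetero atoms), on an aromatic carbon. Among the measured compounds shown here, the only measured step at that carbon is an at least 2.5-fold lower number from compound 2 to compound 3 (0.39 log units; beyond the scatter), which involves a very different leaving group and fixes no direction here. The expectation in this assay is therefore no step beyond the scatter, and the estimated change is a 1.3-fold higher number from compound 3 to compound 4 (0.10 log units; within the scatter). For compound 4 the estimated value is 25000 nM, with an expected range of 8000 nM to 60000 nM.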

Compound 4, half-maximal effective concentration: > 50000 nM
Compound 4: a limit, no number (the forecaster's own chance of this, stated with the estimate: 30%); at least 2.0-fold (0.30 log units) between middle value and limit.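

Here the change at the aromatic carbon next to the ring nitrogen raises the number in this assay: the larger group with its added five-membered aromatic ring gives an at least 2.5-fold higher number from compound 3 to compound 4 (0.39 log units; beyond the scatter), so 4-methylpiperazin-1-yl cannot be swapped for every ring group at this position without a step. Compound 4 gives > 50000 nM, which is a limit and not a number. The step from compound 2 to compound 4 cannot be read: the limit of > 50000 nM in this assay, at which 2 of the 4 values shown sit.

Going by these compounds, how far compound 4 lies past its limit stays open. So does what a smaller amine, such as morpholin-4-yl or dimethylamino, would give at this carbon.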